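Dropping the Drawn Configuration from Compound 3

The compounds below may be only part of what the source reports. "The series", "measured", "known", "first", "only" and "open" are said of these compounds alone.

Of the compounds shown here, three sharing one core have been measured in an in vitro assay on BTI-TN-5B1-4 cells for inhibition of Amine oxidase [flavin-containing] B (Homo sapiens); on this read-out higher numbers stand for weaker inhibition and lower numbers for stronger inhibition. Compound 1 `O=C1C[C@H](c2ccc(F)cc2)Oc2cc(F)ccc21` gives 150 nM. Compound 2 `Cc1ccc(C2CC(=O)c3ccc(F)cc3O2)cc1` gives 160 nM. Compound 3 `Cc1ccc([C@@H]2CC(=O)c3ccc(C)cc3O2)cc1` gives 590 nM, the highest of the three numbers; its gap to compound 2 is beyond the scatter, and so is its gap to compound 1.

Compound 4 `Cc1ccc(C2CC(=O)c3ccc(C)cc3O2)cc1` differs from compound 3 only in how the saturated ring carbon is drawn: the two compounds have the same atoms and bonds; at least one stereo element is drawn with a configuration in one of them and without one in the other: 1 of 1 stereo elements differ; a stereocentre at a saturated ring carbon is drawn S in compound 3 and without a configuration in compound 4. For the measured compounds named here, with no measured pair of this kind to lean on, the expected change is small, with no clear direction beyond the scatter. Compound 4 is therefore estimated at 450 nM, in the range 200 nM to 1200 nM. The step of a 1.3-fold lower number from compound 3 to compound 4 (0.12 log units; within the scatter) is expected to remain within the scatter.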

Compound 4, half-maximal inhibitory concentration: 500 nM
Compound 4: the middle estimate sits 1.1-fold (0.05 log units) below what was measured; low and high end bracket the measured number.
By their numbers in this assay, from the lowest: compounds 1 and 2 (each within the scatter of the next); then compounds 4 and 3 (each within the scatter of the next).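

Drawing the saturated ring carbon without a configuration gives a 1.2-fold lower number from compound 3 to compound 4 (0.07 log units; within the scatter), so the two compounds cannot be told apart on this read-out. Methyl in place of fluoro on an aromatic carbon gives a 3.1-fold higher number from compound 2 to compound 4 (0.49 log units; beyond the scatter), a modest step and the only one here that clears the scatter. The stereo comparison rests on a single point: the fact that one of compounds 3 and 4 is drawn with a defined configuration and the other without, at the place where they differ

The compounds shown leave open how a chloro group or an amine would read on that aromatic carbon. They also leave open how the R configuration at the saturated ring carbon would compare with the S form.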